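This account rests on a few compounds, and the source may have more. Where it says the series, first, only, none or still open, it means among the compounds named here.

Measured in a functional assay on NT2 cells (Homo sapiens) for inhibition; on this read-out lower numbers stand for stronger inhibition and higher numbers for weaker inhibition:
- compound 1 `CCCN(CCC)C(=O)c1cncc(C(=O)N[C@@H](CC(=O)O)C(=O)CSCc2ccc(F)cc2)c1`: > 100000 nM
- compound 2 `CC(C)CN(CC(C)C)C(=O)c1cncc(C(=O)N[C@@H](CC(=O)O)C(=O)CSCc2ccc(F)cc2)c1`: 39000 nM
- compound 3 `CCN(CC)S(=O)(=O)c1cncc(C(=O)N[C@@H](CC(=O)O)C(=O)CSCc2ccc(F)cc2)c1`: 12000 nM

The value of compound 1 is a limit of the assay, so steps from it are bounds.

Compound 3 holds the lowest number in the series at 12000 nM. Its nearest neighbour is compound 2, with a 3.3-fold lower number from compound 2 to compound 3 (0.51 log units; beyond the scatter).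

Compound 4 `CN(C1CC1)S(=O)(=O)c1cncc(C(=O)N[C@@H](CC(=O)O)C(=O)CSCc2ccc(F)cc2)c1` carries cyclopropyl(methyl)amino in place of diethylamino on a sulfonyl sulfur.

Among the measured compounds shown here, no measured step changes the amine on the sulfonyl sulfur. For the measured compounds named here, the closest precedent is an amine change on a carbonyl carbon, an at least 2.5-fold lower number from compound 1 to compound 2 (0.40 log units; beyond the scatter), which shows that such a swap can move this read-out beyond the scatter. The steps of an at least 8.3-fold lower number from compound 1 to compound 3 (0.92 log units; beyond the scatter) and a 3.3-fold lower number from compound 2 to compound 3 (0.51 log units; beyond the scatter) also replace the carbamoyl with a sulfamoyl, so they bear on this change only loosely.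

A small step is therefore expected in this assay, possibly within the scatter, with a slight lean towards a higher number. The expected change is a 1.3-fold higher number from compound 3 to compound 4 (0.10 log units; within the scatter). For compound 4 the estimated value is 15000 nM, with an expected range of 4000 nM to 50000 nM.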

Compound 4, half-maximal inhibitory concentration: 22000 nM
Compound 4: the middle estimate sits 1.5-fold (0.17 log units) below what was measured; the measured number falls inside the stated range.
By their numbers in this assay, from the lowest: compounds 3, 4 and 2 (each within the scatter of the next, the first and the last beyond it). At a limit, above all of these: compound 1.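

In this assay, cyclopropyl(methyl)amino on the sulfonyl sulfur, which has the same heavy-atom count as diethylamino but adds a three-membered ring, gives a 1.8-fold higher number from compound 3 to compound 4 (0.26 log units; within the scatter), so this ring change cannot be told from the scatter. Against the diisobutylcarbamoyl, the cyclopropyl(methyl)sulfamoyl gives a 1.8-fold lower number from compound 2 to compound 4 (0.25 log units; within the scatter), so the separation seen with the diethylsulfamoyl is not retained with this amine. The comparison with the dipropylcarbamoyl can be read only as a bound, set by a limit of the assay: an at least 4.5-fold lower number from compound 1 to compound 4 (0.65 log units; beyond the scatter).

As far as these compounds go, it remains open whether a ring amine such as morpholine or piperidine on the sulfonyl sulfur would move the number beyond the scatter. From the compounds shown here alone, the carboxylic acid is common to all four compounds, so the effect of replacing it with an ester or an amide also remains unknown.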